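Changing the Side Chain of Compound 3

The compounds below may be only part of what the source reports. "The series", "measured", "known", "first", "only" and "open" are said of these compounds alone.

In a functional assay on MGC-803 cells (Homo sapiens) for cytotoxicity, read by MTT assay, with stated times of 48 h and 4 h (a lower number here means a stronger inhibitor, a higher number a weaker inhibitor), compound 1 (`COc1ccc(/C=C/c2nc(NCCN(C(C)C)C(C)C)c3cc(Cl)ccc3n2)cc1OC`) gives 15600 nM, compound 2 (`CC(C)N(CCNc1nc(/C=C/c2ccc([N+](=O)[O-])cc2)nc2ccccc12)C(C)C`) gives 29100 nM and compound 3 (`CC(C)N(CCNc1nc(/C=C/c2ccc([N+](=O)[O-])cc2)nc2ccc(Cl)cc12)C(C)C`) gives 17300 nM, which places compound 3 within the scatter of both others. Compound 4 (`NCCCCNc1nc(/C=C/c2ccc([N+](=O)[O-])cc2)nc2ccc(Cl)cc12`) has 2-aminoethyl in place of diisopropylamino on a saturated chain carbon, two bonds along the chain from a nitrogen on an aromatic ring. The two measured steps, a 1.1-fold higher number from compound 1 to compound 3 (0.04 log units; within the scatter) and a 1.7-fold lower number from compound 2 to compound 3 (0.23 log units; within the scatter), lie elsewhere on the molecule, so neither tests this change directly. With no measured guide on this chain, the expected change is only a 1.4-fold lower number from compound 3 to compound 4 (0.16 log units; within the scatter), which stays within the scatter. For compound 4 the estimated value is 12000 nM, with a wide range from 4000 nM to 35000 nM.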

Compound 4, half-maximal inhibitory concentration: 9160 nM
The estimate for compound 4 lay 1.3-fold (0.12 log units) above the measured number; the measured number falls inside the stated range.
By their numbers in this assay, from the lowest: compounds 4, 1, 3 and 2 (each within the scatter of the next, the first and the last beyond it).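

In this assay, for the compounds shown here, the first measured change on this side chain, 2-(diisopropylamino)ethyl to 4-aminobutyl, gives a 1.9-fold lower number from compound 3 to compound 4 (0.28 log units; within the scatter). So this position accepts a large change in the side chain without a shift beyond the scatter, which the earlier steps, made elsewhere on the molecule, could not show. No supporting measurement explains this result.

Because chain length and the group at its end change together, the compounds shown cannot separate their contributions. From the compounds shown here alone, a 4-(diisopropylamino)butyl chain would separate them, and a morpholine or hydroxyl at the chain end remains open.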